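The compounds below may be only part of what the source reports. "The series", "measured", "known", "first", "only" and "open" are said of these compounds alone.

Of the compounds shown here, two of a shared core have been measured in an assay on isolated protein for binding affinity to adenosine receptor A1 (Bos taurus); a higher number here means a weaker inhibitor, a lower number a stronger inhibitor. Compound 1 `Fc1ccccc1Cn1nnc2c(NC3CC3)nc(-c3ccccc3)nc21` gives 15000000 nM, and compound 2 `OCCNc1nc(-c2ccccc2)nc2c1nnn2Cc1ccccc1` gives 38000000 nM, the higher of the two numbers; compound 1 and compound 2 differ in two places at once, so their values only show that compound 2 is the weaker binder of the pair by a margin beyond the usual scatter. Compound 3 `OCCNc1nc(-c2ccccc2)nc2c1nnn2Cc1ccccc1F` has not yet been measured in this assay. It differs from compound 2 in one place: fluoro in place of hydrogen on an aromatic carbon, on an aromatic carbon of a six-membered aromatic ring of carbon only, ortho to a large group. For the measured compounds named here, no measured pair shows this change alone. A small step is expected, if any, with the number for compound 3 perhaps a little lower than for compound 2 but most likely within the scatter: the step from compound 2 to compound 3 is estimated at a 1.5-fold lower number from compound 2 to compound 3 (0.18 log units; within the scatter). Compound 3 is therefore expected to give about 25000000 nM in this assay, within a range of 8000000 nM to 80000000 nM.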

Compound 3, inhibition constant: 54000000 nM
For compound 3 the middle estimate is 2.2-fold (0.33 log units) below the measured one, within the range that was stated.
By their numbers in this assay, from the lowest: compound 1; then compounds 2 and 3 (each within the scatter of the next).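

In this assay, replacing hydrogen with fluoro, which turns benzyl into 2-fluorobenzyl, gives a step that is within the scatter (a 1.4-fold higher number from compound 2 to compound 3 (0.15 log units; within the scatter)), so at this place, ortho to a large group, the two compounds cannot be told apart. For the compounds shown here, compound 3 also gives the first comparison that changes only the group on the nitrogen on an aromatic ring: 2-hydroxyethyl in place of cyclopropyl weakens binding modestly (a 3.6-fold higher number from compound 1 to compound 3 (0.56 log units; beyond the scatter)), with the 2-fluorobenzyl group the same in both compounds. Nothing available explains either step.

Going by these compounds, whether a chloro or methoxy group at this ortho place would shift the number remains open. So does how an amine or a longer chain on that nitrogen would compare with 2-hydroxyethyl and cyclopropyl.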